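The source may report more compounds than this note shows. Statements on the series, on what has been measured and on what is new or still open speak of the compounds shown alone.

Measured so far in an ADME assay on HEL cells (Homo sapiens) for cytotoxicity, with a stated time of 3 days; a higher number here means that more compound is tolerated, a lower number that less compound is tolerated:
- compound 1 `Cc1cc(-c2ccc(O)cc2)cn2c(CSCCc3ccccc3)cnc12`: >= 100 ug/mL, a limit of the assay
- compound 2 `Cc1cc(I)c2ncc(CSCCc3ccccc3)n2c1`: >= 4 ug/mL, a limit of the assay
- compound 3 `Cc1cc(-c2cccs2)c2ncc(CSCCc3ccccc3)n2c1`: 100 ug/mL

Compound 1 is known in this assay only as a limit, >= 100 ug/mL, which places it at the limit of >= 100 ug/mL in this assay, at which 1 of the 3 values shown sits. For compound 2 the reading is likewise a limit, >= 4 ug/mL, sitting at the limit of >= 4 ug/mL in this assay, at which 1 of the 3 values shown sits. Compound 3 alone gives a number, 100 ug/mL. Within the data shown here, the single pairwise step in the set, a step that the limit leaves unreadable from compound 2 to compound 3, is therefore not readable in size, and no step touching the hydroxyphenyl group of compound 1 has been measured at all.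

Compound 4 `COc1ccc(-c2cc(C)c3ncc(CSCCc4ccccc4)n3c2)cc1` differs from compound 1 by methyl in place of hydrogen on an oxygen on an aromatic ring. Among the measured compounds shown here, nothing measured bears on this change: the one step on record is unreadable, and both compounds with the phenyl-type substituent sit at or near the top of the range tested. No step beyond the scatter is expected in this assay in either direction from compound 1 to compound 4; the expected step is a number no higher from compound 1 to compound 4 (the limit leaves the size open). Compound 4 is estimated at 100 ug/mL, with a range from 25 ug/mL to 100 ug/mL, and it is expected that the assay may again report only a limit for compound 4.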

Compound 4, minimum cytotoxic concentration: 20 ug/mL
The estimate for compound 4 lay 5.0-fold (0.70 log units) above the measured number; the measured number lies below the stated range.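

In this assay compound 1 gives >= 100 ug/mL, which is a limit of the assay. Methyl in place of hydrogen on the oxygen on the aromatic ring, 4-hydroxyphenyl to 4-methoxyphenyl, gives an at least 5.0-fold lower number from compound 1 to compound 4 (0.69 log units; beyond the scatter), so the series responds at this position to a change as small as hydroxy to methoxy, and this is the only readable step among the compounds shown. The values shown give no reason for this step.

Among these compounds, the step from compound 2 to compound 3 cannot be read, and its limit leaves open how the aryl-type groups compare with iodo, while the single hydroxy to methoxy pair cannot show whether the step belongs to this change alone or would hold on the thiophen-2-yl series or elsewhere on the shared core. From the compounds shown here alone, how an ethyl group or a longer chain on that oxygen, or an amine or a carboxylic acid in place of the hydroxy, would read in this assay also stays open.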